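Cyclopentyl in Place of Fluorophenyl: an Expected Binding Shift

This account rests on a few compounds, and the source may have more. Where it says the series, first, only, none or still open, it means among the compounds named here.

Compound 1, `O=c1cc(-c2ccccc2)oc2ccc(OCCCCCCN3CCC(O)CC3)cc12`, gives 100 nM in an assay on isolated protein (Cavia porcellus) with Sigma non-opioid intracellular receptor 1 (Homo sapiens) as the target, read by radioligand binding; a higher number here means a weaker inhibitor, a lower number a stronger inhibitor.
Compound 2, `O=c1cc(-c2ccc(F)cc2)oc2ccc(OCCCCCCN3CCC(O)CC3)cc12`, gives 95 nM in this assay.

Compound 2 stands at the lower of the two numbers, but its gap to compound 1 is small: a 1.1-fold lower number from compound 1 to compound 2 (0.02 log units; within the scatter). The two compounds are therefore indistinguishable in this assay.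

Compound 3, `O=c1cc(C2CCCC2)oc2ccc(OCCCCCCN3CCC(O)CC3)cc12`, has not been measured. It differs from compound 2 in one place: cyclopentyl in place of 4-fluorophenyl on an aromatic carbon. Within the data shown here, the only measured step, from hydrogen to fluoro on the same aromatic ring, is a far smaller change than removing the aromatic ring altogether, so it gives little guidance. Among the measured compounds shown here, with no step in hand that exchanges an aromatic ring for a non-aromatic one, the size and direction of the change remain open, and a somewhat weaker binding is the more cautious guess. Compound 3 is expected to give 200 nM, with a range from 60 nM to 700 nM. That estimate corresponds to a 2.1-fold higher number from compound 2 to compound 3 (0.32 log units; beyond the scatter).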

Compound 3, half-maximal inhibitory concentration: 51 nM
Compound 3: middle estimate off by 3.9-fold (0.59 log units), on the high side, and the stated range ends above it.
By their numbers in this assay, from the lowest: compounds 3, 2 and 1 (each within the scatter of the next).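

The carbon next to the ring oxygen accepts a non-aromatic ring as well as an aromatic one in this assay: cyclopentyl in place of 4-fluorophenyl gives a 1.9-fold lower number from compound 2 to compound 3 (0.27 log units; within the scatter) and cyclopentyl in place of phenyl gives a 2.0-fold lower number from compound 1 to compound 3 (0.29 log units; within the scatter) in the same assay. Both steps stay within the scatter, so even this exchange of a whole ring leaves the three compounds indistinguishable, just as the swap of hydrogen for fluoro did. No measurement at hand explains this tolerance.

On these data alone, it remains open whether other groups at this carbon, such as cyclohexyl, a simple methyl or a ring containing an amine nitrogen, would also stay within the scatter. The compounds shown also cannot tell whether the same tolerance would hold with a chain other than the six-carbon one.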